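Pyridin-3-yl for 3-chlorophenyl at the solubility limit

This account rests on a few compounds, and the source may have more. Where it says the series, first, only, none or still open, it means among the compounds named here.

Measured in a physicochemical assay for solubility, read by LC-MS, using the shake flask method, measured as thermodynamic solubility, with a stated time of 24 h, at pH 6.5; on this read-out higher numbers stand for higher solubility and lower numbers for lower solubility:
Compound 1 `O=[N+]([O-])c1ccc(-n2cc(CCO[C@H]3O[C@H](CO)[C@@H](O)[C@H](O)[C@@H]3O)nn2)cc1`: > 3000 ug/mL
Compound 2 `Cc1ccc(-c2cn(C[C@H]3O[C@H](CO)[C@@H](O)[C@H](O)[C@@H]3O)nn2)cc1`: 1490 ug/mL
Compound 3 `OC[C@H]1O[C@H](Cn2cc(-c3cccc(Cl)c3)nn2)[C@@H](O)[C@@H](O)[C@@H]1O`: > 3000 ug/mL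

For compound 3, the reading > 3000 ug/mL is a limit and not a number. For compound 1, the reading > 3000 ug/mL is also a limit. On these data alone, compound 3 therefore stands at the limit of > 3000 ug/mL in this assay, at which 2 of the 3 values shown sit, and its exact value is unknown.

Compound 4 `OC[C@H]1O[C@H](Cn2cc(-c3cccnc3)nn2)[C@@H](O)[C@@H](O)[C@@H]1O` differs from compound 3 by a single change, pyridin-3-yl in place of 3-chlorophenyl on an aromatic carbon. Within the data shown here, one measured step bears on this, and it too exchanges one aromatic group for another on an aromatic carbon: an at least 2.0-fold higher number from compound 2 to compound 3 (0.30 log units; that floor lies within the scatter). That floor lies within the scatter, so no step beyond the scatter is expected in this assay, in either direction. The expected change, a number no higher from compound 3 to compound 4 (the limit leaves the size open), is only an estimate, and the measurement may again return just a limit. For compound 4, the expected solubility is 3000 ug/mL, with an estimated range from 1500 ug/mL to 6000 ug/mL.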

Compound 4, solubility: 1880 ug/mL
Compound 4: middle estimate off by 1.6-fold (0.20 log units), on the high side; low and high end bracket the measured number.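

In this assay, putting a ring with one hetero atom in place of the carbon-only ring of compound 3 gives an at least 1.5-fold lower number from compound 3 to compound 4 (0.20 log units; that floor lies within the scatter), so this exchange shows no step beyond the scatter at this position. Set against 4-methylphenyl, the same pyridin-3-yl gives a 1.3-fold higher number from compound 2 to compound 4 (0.10 log units; within the scatter), which means compound 2 and compound 4 cannot be told apart on this read-out. The first step is only a floor, and its true size stays unknown, because compound 3 sits at a limit of the assay: the limit of > 3000 ug/mL in this assay, at which 2 of the 4 values shown sit.

The compounds shown leave open whether moving the ring nitrogen, as in pyridin-4-yl, would change the reading. They also leave open how an amine or a carboxylic acid on this aromatic ring would read.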